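Switching a Benzylamine to an Anilines Partner on a Shared Core

A few compounds are considered here, and "the series" means these few. Any claim that something is new, unique, unknown or untested is made for them only; others in the source may bear on it.

Measured compounds:
compound 1, `Cc1ccccc1Nc1nc(Nc2ccc(N3CCN(C)CC3)cc2)ncc1Cl`, 20600 nM
compound 2, `COc1ccc(CNc2nc(Nc3ccc(N4CCN(C)CC4)cn3)ncc2Cl)cc1`, 17300 nM

Of the compounds shown here, two have been tested so far in a functional assay on MCF7 cells (Homo sapiens) for inhibition, read by CCK-8 assay, with a stated time of 48 h; a lower number here means a stronger inhibitor of growth, a higher number a weaker inhibitor of growth. Compound 1 gives 20600 nM, and compound 2 gives 17300 nM. Of the two numbers, that of compound 2 is the lower one, but the gap to compound 1 lies within the usual scatter of this assay, so the two compounds cannot be placed in any order on these data alone. Both sit in the weak range.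

Compound 3, `COc1cccc(Nc2nc(Nc3ccc(N4CCN(C)CC4)cn3)ncc2Cl)c1`, has not yet been measured. It differs from compound 2 in one place: 3-methoxyphenyl in place of 4-methoxybenzyl on a nitrogen on an aromatic ring. For the measured compounds named here, no step between two measured compounds carries that change, so there is no measured precedent to lean on, and the expectation rests on the structural change alone.

The change is expected to move the number downward, by a moderate step, as a 2.2-fold lower number from compound 2 to compound 3 (0.33 log units; beyond the scatter) in this assay. For compound 3 the estimate is 8000 nM, with a range from 2000 nM to 30000 nM.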

Compound 3, concentration for 50% growth inhibition: 7540 nM
Beside the measured number, compound 3's estimate is 1.1-fold (0.03 log units) above it; the measured number falls inside the stated range.
By their numbers in this assay, from the lowest: compound 3; then compounds 2 and 1 (each within the scatter of the next).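

In this assay, the exchange of 4-methoxybenzyl for 3-methoxyphenyl on the nitrogen gives a 2.3-fold lower number from compound 2 to compound 3 (0.36 log units; beyond the scatter), a modest change but one beyond the scatter, and so the first sign that the number responds to the group at this position, which compounds 1 and 2, differing in more than one place, could not show. For the compounds shown here, the exchange combines two differences, since the aromatic ring of the entering group sits directly on the nitrogen and the methoxy group has a different place on that ring, and the single step cannot divide its size between them. Nothing at hand accounts for the lower number of compound 3.

The compounds shown leave open whether a 3-methoxybenzyl or a 4-methoxyphenyl group, each of which would carry only one of those two differences, would give the same shift. They also leave open how this position would respond to an unsubstituted phenyl ring, a hydroxyl group or an amine on the ring in place of the methoxy group, and whether the step would hold on another core.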